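Growing the Saturated Ring Substituent on the Shared Core

The source may report more compounds than this note shows. Statements on the series, on what has been measured and on what is new or still open speak of the compounds shown alone.

Three compounds that share one core are compared in a functional assay on HEK293 cells for activation of melanin-concentrating hormone receptor 1 (Rattus norvegicus), read by inositol phosphate accumulation; on this read-out higher numbers stand for an effect only at larger amounts of compound and lower numbers for an effect already at smaller amounts. Compound 1 `CNC(=O)NC1CCN(c2ccc3cc(NC(=O)CCc4ccc(C(F)(F)F)cc4)ccc3n2)C1` gives 30 nM. Compound 2 `CC1CCN(c2ccc3cc(NC(=O)CCc4ccc(C(F)(F)F)cc4)ccc3n2)C1` gives 400 nM, and compound 3 `CC1CCCN1c1ccc2cc(NC(=O)CCc3ccc(C(F)(F)F)cc3)ccc2n1` gives 270 nM. Among these numbers compound 3 has the second highest, close to compound 2 and far from compound 1: a 1.5-fold lower number from compound 2 to compound 3 (0.17 log units; within the scatter), whereas a 9.0-fold higher number from compound 1 to compound 3 (0.95 log units; beyond the scatter).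

Compound 4 `O=C(CCc1ccc(C(F)(F)F)cc1)Nc1ccc2nc(N3CCC4(CCNC4)C3)ccc2c1` is not yet measured. It differs from compound 3 in one place: a group of 9 heavy atoms (7 carbon, 2 nitrogen; 2 five-membered non-aromatic rings with 1 hetero atom each) in place of a group of 6 heavy atoms (5 carbon, 1 nitrogen; one five-membered non-aromatic ring with 1 hetero atom), on an aromatic carbon. The group that enters carries one hydrogen-bond donor, which 2-methylpyrrolidin-1-yl lacks. The measured steps that bear on this are those leading away from compound 1, whose 3-((methylcarbamoyl)amino)pyrrolidin-1-yl also carries hydrogen-bond donors: a 13-fold higher number from compound 1 to compound 2 (1.12 log units; beyond the scatter) and a 9.0-fold higher number from compound 1 to compound 3 (0.95 log units; beyond the scatter). In both, the substituent without a hydrogen-bond donor gives the markedly higher number in this assay. Compound 4 is therefore expected to show a lower number than its neighbour, with the step estimated as a 2.7-fold lower number from compound 3 to compound 4 (0.43 log units; beyond the scatter). Within the data shown here, the entering group is not the one found in compound 1, so a smaller step than those two is expected. The estimate for compound 4 is 100 nM, with a range from 30 nM to 400 nM.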

Compound 4, half-maximal effective concentration: 140 nM
Compound 4: middle estimate off by 1.4-fold (0.15 log units), on the low side, and the stated range covers the measured number.
By their numbers in this assay, from the lowest: compound 1; then compounds 4, 3 and 2 (each within the scatter of the next, the first and the last beyond it).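

At this position, on an aromatic carbon next to the ring nitrogen, a group of 9 heavy atoms with 2 five-membered non-aromatic rings and 1 hydrogen-bond donor can take the place of a single substituted pyrrolidine ring without a loss in this assay: the comparison with 2-methylpyrrolidin-1-yl gives a 1.9-fold lower number from compound 3 to compound 4 (0.29 log units; within the scatter), while the comparison with 3-methylpyrrolidin-1-yl gives a 2.9-fold lower number from compound 2 to compound 4 (0.46 log units; beyond the scatter). A hydrogen-bond donor on the entering group does not, however, match the number obtained with 3-((methylcarbamoyl)amino)pyrrolidin-1-yl, as the step of a 4.7-fold higher number from compound 1 to compound 4 (0.67 log units; beyond the scatter) shows, so the two donor-bearing groups are not interchangeable here. No measurement is available that would explain these differences.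

The compounds shown do not separate the contribution of the hydrogen-bond donor from that of the added ring and the larger group. A methyl or acetyl group on the free ring amine of the entering group, or a plain 3-aminopyrrolidin-1-yl on the shared core, would be needed to tell these apart in this assay.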